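A fluoro step on the benzoyl arm in MT4 cells

This account rests on a few compounds, and the source may have more. Where it says the series, first, only, none or still open, it means among the compounds named here.

Compound 1 `CCc1c(Cc2c(F)cccc2Cl)nc(SCC(=O)c2ccccc2)[nH]c1=O` and compound 2 `CCc1c(Cc2c(F)cccc2Cl)nc(SCC(=O)c2ccc(F)cc2)[nH]c1=O` share one core and differ by fluoro in place of hydrogen on an aromatic carbon. In an ADME assay on MT4 cells (Homo sapiens) for cytotoxicity, read by MTT assay (a lower number here means that less compound is tolerated, a higher number that more compound is tolerated), compound 1 gives only a limit of the assay, > 12000 nM. Compound 2 likewise gives only a limit in this assay, > 57000 nM. The step that the two limits leave unreadable from compound 1 to compound 2 cannot be sized, since both the limit of > 12000 nM in this assay, at which 1 of the 3 values shown sits, and the limit of > 57000 nM in this assay, at which 1 of the 3 values shown sits, are limits rather than numbers.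

Compound 3 `CC(C)c1c(Cc2c(F)cccc2F)nc(SCC(=O)c2ccccc2)[nH]c1=O` carries a different core, and how it differs from compound 1 is not broken down here. In this assay compound 3 also gives only a limit, > 60000 nM, recorded as the limit of > 60000 nM in this assay, at which 1 of the 3 values shown sits. Compound 4 `CC(C)c1c(Cc2c(F)cccc2F)nc(SCC(=O)c2ccc(F)cc2)[nH]c1=O` has not yet been measured and differs from compound 3 by fluoro in place of hydrogen on an aromatic carbon. The place of this change is the same as that between compound 1 and compound 2, so it is the same change, occurring twice among these four compounds.

The measured pair gives no size for this change; what is known is that compound 1, compound 2 and compound 3 all sit at limits. Compound 4 is therefore expected to sit at a limit as well, with an estimated step that the limit leaves unreadable from compound 3 to compound 4 in this assay. That expectation rests on compound 3 giving > 60000 nM. For compound 4 the estimate in this assay is 80000 nM, with an expected range from 40000 nM to 200000 nM.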

Compound 4, half-maximal cytotoxic concentration: > 58000 nM
Compound 4 gave a limit, no number (the forecaster's own chance of this, stated with the estimate: 85%); the middle value lies beyond the limit too.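

Compound 3 and compound 4 both give only limits in this assay, and the step between them cannot be read; the same holds for the step from compound 1 to compound 2. The compounds shown leave open how large the change from phenyl to 4-fluorophenyl is in this assay, or whether it has any size there at all, as none of the four gives a number.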